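This account rests on a few compounds, and the source may have more. Where it says the series, first, only, none or still open, it means among the compounds named here.

Compounds measured so far:
compound 2 `CNS(=O)(=O)c1ccc(Nc2ncc3c(n2)N(C)C(c2ccccc2C)C(=O)N3C)cc1`: 104 nM
compound 1 `CNS(=O)(=O)c1ccc(Nc2ncc3c(n2)N(C)C(c2c(F)cccc2F)C(=O)N3C)cc1`: 318 nM

Both were tested in an assay on Sf9 cells for inhibition of serine/threonine-protein kinase 4 (Homo sapiens), read by luminescence and ADP-Glo, with a stated time of 1 h, in the presence of a further agent that is not named here; on this read-out higher numbers stand for weaker inhibition and lower numbers for stronger inhibition. Among these two numbers compound 2 stands lowest; its only neighbour is compound 1, and the single measured step, a 3.1-fold lower number from compound 1 to compound 2 (0.49 log units; beyond the scatter), separates them.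

Compound 3 `CCNS(=O)(=O)c1ccc(Nc2ncc3c(n2)N(C)C(c2ccccc2C)C(=O)N3C)cc1` has not been measured. It differs from compound 2 by methyl in place of hydrogen on a saturated chain carbon bound to a sulfonamide nitrogen. The measured step concerns an exchange of one aromatic ring for another at a saturated ring carbon of the shared core, a different place from the sulfonamide end of the molecule, so it gives no direct guidance here. Going by the values given here, with no step at that position in hand, the plain expectation is that the small change leaves the number where compound 2 sits, with no step beyond the scatter. The estimated step is no change at the digits printed from compound 2 to compound 3 (within the scatter). Compound 3 is therefore expected to give 104 nM, within a range from 40 nM to 270 nM.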

Compound 3, half-maximal inhibitory concentration: 119 nM
Estimate against measurement, compound 3: 1.1-fold (0.06 log units) below, within the range that was stated.
By their numbers in this assay, from the lowest: compounds 2 and 3 (each within the scatter of the next); then compound 1.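

Going by these compounds alone, until now the only measured step lay at the aromatic ring on a saturated ring carbon of the shared core, whereas this one lies at the sulfonamide end of the molecule. In this assay, going from methylsulfamoyl to ethylsulfamoyl gives a 1.1-fold higher number from compound 2 to compound 3 (0.06 log units; within the scatter) and so the two numbers cannot be told apart, which shows that this one added methyl on the sulfonamide chain can be carried without a measurable effect on the read-out. Nothing available explains why the number holds at this position.

From the compounds shown here alone, whether a longer chain such as propyl, or a chain ending in an amine or a carboxylic acid, would also hold the number remains open. So does whether ethylsulfamoyl behaves the same way alongside the 2,6-difluorophenyl group of compound 1.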